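The compounds below may be only part of what the source reports. "The series", "measured", "known", "first", "only" and "open" are said of these compounds alone.

In a physicochemical assay for solubility, in phosphate buffer, measured as kinetic solubility, at pH 7.4 (on this read-out higher numbers stand for higher solubility and lower numbers for lower solubility), compound 1 `Cc1oc(-c2c(Cl)cccc2Cl)nc1CN1CCC(C(=O)NCCCN2C[C@H](C)C[C@H](C)C2)CC1` gives > 77 ug/mL, which is a limit of the assay and not a number. Going by the values given here, compound 2 `Cc1cccc(C)c1-c1nc(CN2CCC(C(=O)NCCCN3C[C@H](C)C[C@H](C)C3)CC2)c(C)o1` gives 55.9 ug/mL, the only true number so far in this assay. Compound 3 `Cc1ccc(-c2nc(CN3CCC(C(=O)NCCCN4C[C@H](C)C[C@H](C)C4)CC3)c(C)o2)cc1C` has the same atoms as compound 2, joined differently: 3,4-dimethylphenyl in place of 2,6-dimethylphenyl on an aromatic carbon. It carries 3,4-dimethylphenyl in place of 2,6-dimethylphenyl on an aromatic carbon. Among the compounds with values here, only one measured step bears on this change, an at least 1.3-fold lower number from compound 1 to compound 2 (0.13 log units; that floor lies within the scatter), and its full size stays open because of the limit of > 77 ug/mL in this assay, at which 1 of the 2 values shown sits. That step exchanges one group for another, whereas the new change only relocates the two methyl groups, so it offers weak guidance. No step beyond the scatter is therefore expected, and the expected step is a 1.1-fold lower number from compound 2 to compound 3 (0.05 log units; within the scatter). For compound 3 the expected value is 50 ug/mL, with an estimated range from 22 ug/mL to 80 ug/mL.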

Compound 3, solubility: > 71 ug/mL
Compound 3 ended at the assay's limit (the forecaster's own chance of this, stated with the estimate: 20%); at least 1.4-fold (0.15 log units) between middle value and limit.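

In this assay, going by these compounds alone, the pair offers the first change that only relocates the two methyl groups at this position on the five-membered aromatic ring, with 3,4-dimethylphenyl in place of 2,6-dimethylphenyl, and it gives an at least 1.2-fold higher number from compound 2 to compound 3 (0.10 log units; that floor lies within the scatter). The reading of compound 3 is a limit and not a number, so the full size of this step stays open: the limit of > 71 ug/mL in this assay, at which 1 of the 3 values shown sits. The reading of compound 1 is also a limit, and the step from it to compound 3 cannot be read: the limit of > 77 ug/mL in this assay, at which 1 of the 3 values shown sits.

The compounds shown do not settle whether relocating the methyl groups moves the number beyond the scatter. They also leave open what an unsubstituted phenyl, a single methyl group, or a carboxylic acid on the phenyl ring would give at this position.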